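From hydroxy to methoxy in a small series

This account rests on a few compounds, and the source may have more. Where it says the series, first, only, none or still open, it means among the compounds named here.

Values in a functional assay on HepG2 cells (Homo sapiens) for inhibition, read by MTT assay, with a stated time of 72 h; a higher number here means a weaker inhibitor, a lower number a stronger inhibitor
compound 1 `COc1ccc(/C=C/C(=O)c2c(OC)cc(O)c(CC=C(C)C)c2O)cc1OC` 13800 nM
compound 2 `COc1ccc(/C=C/C(=O)c2c(O)cc(O)cc2OC)cc1` 18100 nM
compound 3 `COc1cc(/C=C/C(=O)c2c(O)cc(O)cc2OC)ccc1O` > 50000 nM (a limit)

Of the compounds shown here, three have so far been tested in this assay, and compound 3 is the only one without a numerical result. Compound 3 gives > 50000 nM, which is a limit and not a number. Compound 1 gives 13800 nM and compound 2 gives 18100 nM, two values that lie within the usual scatter of each other.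

Compound 4 `COc1ccc(/C=C/C(=O)c2c(O)cc(O)cc2OC)cc1OC` has not yet been measured. It differs from compound 3 in one place: methyl in place of hydrogen on an oxygen on an aromatic ring. This is a change from hydroxy to methoxy, with methyl in place of hydrogen on an oxygen on an aromatic ring.

Within the data shown here, no pair of measured compounds shows this change on its own, so its size can only be judged indirectly. Like compound 1 at 13800 nM and compound 2 at 18100 nM, compound 4 carries a methoxy where compound 3 has its hydroxy. A move towards a stronger inhibitor is therefore expected, and the expected step is an at least 2.0-fold lower number from compound 3 to compound 4 (0.30 log units; that floor lies within the scatter). Compound 4 is expected at about 25000 nM, with an estimated range from 10000 nM to 50000 nM.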

Compound 4, half-maximal inhibitory concentration: 18500 nM
For compound 4 the middle estimate is 1.4-fold (0.13 log units) above the measured one, within the range that was stated.
By their numbers in this assay, from the lowest: compounds 1, 2 and 4 (each within the scatter of the next). At a limit, above all of these: compound 3.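

In this assay, among these compounds, methyl in place of hydrogen on an oxygen on an aromatic ring gives an at least 2.7-fold lower number from compound 3 to compound 4 (0.43 log units; beyond the scatter), the first direct reading of this change from hydroxy to methoxy that the series offers. Its full size remains unknown, since compound 3 stands at a limit and not a number: the limit of > 50000 nM in this assay, at which 1 of the 4 values shown sits.

The two other changes that end at compound 4 stay within the scatter: methoxy in place of hydrogen on an aromatic carbon gives a 1.0-fold higher number from compound 2 to compound 4 (0.01 log units; within the scatter), and hydrogen in place of 3-methylbut-2-en-1-yl on an aromatic carbon gives a 1.3-fold higher number from compound 1 to compound 4 (0.13 log units; within the scatter).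

What the compounds shown leave open is whether an ethoxy group, a longer chain on the same oxygen or an amine in its place would give a number like that of compound 4. They also leave open whether the change from hydroxy to methoxy would give a step of similar size on a core that carries the 3-methylbut-2-en-1-yl group, as compound 1 does.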